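The source may hold more compounds than are shown below. What is called first, only, known or untested is meant among the compounds shown, and "the series" means these compounds.

In a functional assay on HeLa cells (Homo sapiens) for cytotoxicity, read by resazurin assay, with a stated time of 24 h (on this read-out higher numbers stand for weaker inhibition and lower numbers for stronger inhibition), compound 3 `CC(=O)C(C)Nc1ccc(C(=O)Nc2ccn([C@H]3CC[C@H](O[C@H]4O[C@H](C)[C@@H](N(C)C)[C@H](O)[C@H]4O)[C@@H](C)O3)c(=O)n2)cc1` gives 16 ug/mL, level with compound 1 `C[C@H]1O[C@H](O[C@H]2CC[C@H](n3ccc(NC(=O)c4ccc(N)cc4)nc3=O)O[C@@H]2C)[C@H](O)[C@@H](O)[C@@H]1N(C)C` at 16 ug/mL, while compound 2 `CS/C=C/C(=O)Nc1ccn([C@H]2CC[C@H](O[C@H]3O[C@H](C)[C@@H](N(C)C)[C@H](O)[C@H]3O)[C@@H](C)O2)c(=O)n1` gives 1 ug/mL. Compound 4 `C[C@H]1O[C@H](O[C@H]2CC[C@H](n3ccc(NC(=O)c4ccc(F)cc4)nc3=O)O[C@@H]2C)[C@H](O)[C@@H](O)[C@@H]1N(C)C` differs from compound 3 as follows: fluoro in place of (1-acetylethyl)amino on an aromatic carbon. In words, this is fluoro in place of (1-acetylethyl)amino on an aromatic carbon, para to a large group.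

Two kinds of measured step bear on this change. Changing the substituent on the aromatic amine nitrogen gave no change at the digits printed from compound 1 to compound 3 (within the scatter), so altering that group while keeping the phenyl ring left the number in place. Replacing the whole substituted phenyl group mattered far more, giving a 16-fold lower number from compound 1 to compound 2 (1.20 log units; beyond the scatter) and a 16-fold higher number from compound 2 to compound 3 (1.20 log units; beyond the scatter). Going by the values given here, compound 4 keeps the phenyl ring, but no measured compound carries fluoro, so this expectation is uncertain. The expected outcome in this assay is a small move toward a lower number, within the scatter: a 1.3-fold lower number from compound 3 to compound 4 (0.12 log units; within the scatter). For compound 4 the estimated value is 12 ug/mL, with an expected range of 4 ug/mL to 32 ug/mL.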

Compound 4, half-maximal inhibitory concentration: > 64 ug/mL
Compound 4: no number, only a limit; the forecaster's own chance of this, stated with the estimate: 10%; at least 5.3-fold (0.72 log units) between middle value and limit.
By their numbers in this assay, from the lowest: compound 2; then compounds 1 and 3 (each within the scatter of the next). At a limit, above all of these: compound 4.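

In this assay, compound 4 gives a limit of the assay rather than a number: the limit of > 64 ug/mL in this assay, at which 1 of the 4 values shown sits. Going by these compounds alone, the earlier compounds showed only that the amino group could gain a 1-acetylethyl group on its nitrogen without moving the number, but this aromatic carbon, para to a large group, proves sensitive once fluoro takes the place of the nitrogen group, with an at least 4.0-fold higher number from compound 3 to compound 4 (0.60 log units; beyond the scatter) and an at least 4.0-fold higher number from compound 1 to compound 4 (0.60 log units; beyond the scatter). Keeping the phenyl ring is therefore not enough to hold the number at the level of compound 1 and compound 3, and the distance to the 2-(methylsulfanyl)ethenyl compound grows, with an at least 64-fold higher number from compound 2 to compound 4 (1.80 log units; beyond the scatter).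

Whether a nitrogen on this carbon is what matters remains open, since only amino, (1-acetylethyl)amino and fluoro are shown there. A hydroxyl, a methoxy or a chloro on the same carbon would help separate the role of nitrogen from that of fluoro.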